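Same Atoms, Joined Differently: Expecting Compound 4

The source may report more compounds than this note shows. Statements on the series, on what has been measured and on what is new or still open speak of the compounds shown alone.

Compound 3 `Cc1nc(S(C)(=O)=O)ccc1Oc1ncnc(OC2CCN(C(=O)c3noc(C(C)(C)F)n3)CC2)c1F` gives 103 nM in a functional assay on isolated protein for inhibition of Glucose-dependent insulinotropic receptor (Rattus norvegicus), read by HTRF and cAMP accumulation (a lower number here means that less compound is needed, a higher number that more compound is needed for the effect), the lowest of the three measured numbers. Compound 2 `Cc1nc(S(C)(=O)=O)ccc1Oc1ncnc(OC2CCN(C(=O)C(F)(F)F)CC2)c1F` gives 880 nM in this assay, and compound 1 `Cc1nc(S(C)(=O)=O)ccc1Oc1ncnc(OC2CCN(C(=O)O[C@H](C)CF)CC2)c1F` gives 1520 nM. The recorded steps are a 1.7-fold lower number from compound 1 to compound 2 (0.24 log units; within the scatter), a 15-fold lower number from compound 1 to compound 3 (1.17 log units; beyond the scatter) and an 8.5-fold lower number from compound 2 to compound 3 (0.93 log units; beyond the scatter); the two steps that end at compound 3 both place the five-membered aromatic ring with 3 hetero atoms on the carbonyl carbon and lower the number beyond the scatter.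

Compound 4 `Cc1nc(S(C)(=O)=O)ccc1Oc1ncnc(OC2CCN(C(=O)c3nc(C(C)(C)F)no3)CC2)c1F` differs from compound 3 by a group of 9 heavy atoms (5 carbon, 2 nitrogen, 1 oxygen, 1 fluorine; one five-membered aromatic ring with 3 hetero atoms) in place of a group of 9 heavy atoms (5 carbon, 2 nitrogen, 1 oxygen, 1 fluorine; one five-membered aromatic ring with 3 hetero atoms), on a carbonyl carbon; the two have the same atoms, joined differently. Among the compounds with values here, no measured step alters only the way this ring is joined, so the known steps give context alone: the ring itself, replacing groups without a ring, produced the large drops. For a change of connectivity no direction can be read from these data, and a step within the scatter is expected, a 1.5-fold higher number from compound 3 to compound 4 (0.16 log units; within the scatter). Compound 4 is therefore estimated at 150 nM, with a range from 50 nM to 450 nM.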

Compound 4, half-maximal effective concentration: 606 nM
Beside the measured number, compound 4's estimate is 4.0-fold (0.61 log units) below it; measured number above the stated range.
By their numbers in this assay, from the lowest: compound 3; then compounds 4, 2 and 1 (each within the scatter of the next, the first and the last beyond it).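

In this assay, the way the ring is joined matters in its own right: with the same atoms on the carbonyl carbon, a 5.9-fold higher number from compound 3 to compound 4 (0.77 log units; beyond the scatter). A ring at this position is therefore not enough by itself, since a 1.5-fold lower number from compound 2 to compound 4 (0.16 log units; within the scatter), which lies within the scatter, and a 2.5-fold lower number from compound 1 to compound 4 (0.40 log units; beyond the scatter), a beyond-scatter drop but a much smaller one than compound 3 achieves against compound 1. No measurement shown here accounts for this difference between the two ways of joining the ring.

From the compounds shown here alone, it remains open whether a pyridine ring or a 1,3,4-oxadiazole on this carbonyl carbon would give numbers nearer to compound 3 or to compound 4. Going by these compounds, it is also open whether either joining of the ring would hold its number if an isopropyl or a tert-butyl group took the place of the fluorine-bearing group on the ring.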